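A Hydroxy Removed from Compound 1: What to Expect

A few compounds are considered here, and "the series" means these few. Any claim that something is new, unique, unknown or untested is made for them only; others in the source may bear on it.

Measured compounds:
compound 1, `O=C(CN1CC(CO)=CC[C@H](NC(=O)c2ccc3ccccc3c2)C1=O)N[C@H]1CC(=O)OC1O`: 543 nM
compound 2, `O=C(CN1CC=CC[C@H](NC(=O)c2cccc(Cl)c2)C1=O)N[C@H]1CC(=O)OC1O`: 383 nM
compound 3, `O=C[C@H](CC(=O)O)NC(=O)[C@@H]1CC[C@@H]2C/C=C\C[C@H](NC(=O)c3nccc4ccccc34)C(=O)N21`: 188 nM

Of the compounds shown here, three have been measured in a functional assay on THP-1 cells (Homo sapiens) for inhibition; on this read-out lower numbers stand for stronger inhibition and higher numbers for weaker inhibition. Compound 1 gives 543 nM, the highest of the three numbers. Compound 2 gives 383 nM, which lies within the scatter of the value of compound 1, so the two cannot be ordered. Compound 3 gives 188 nM, a lower number that lies beyond the scatter, so compound 3 is the stronger inhibitor of that pair.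

Compound 4, `CC1=CC[C@H](NC(=O)c2ccc3ccccc3c2)C(=O)N(CC(=O)N[C@H]2CC(=O)OC2O)C1`, has not yet been measured. It differs from compound 1 as follows: hydrogen in place of hydroxy on a saturated chain carbon bound to a double-bonded ring carbon. Going by the values given here, no measured pair shows this same change, so the data give no direct precedent for its size. The change is small in atoms, and the expectation is that the step in this assay stays within or only slightly beyond the scatter, if anything toward a weaker inhibitor with a somewhat higher number.

Compound 4 is therefore estimated at 700 nM, with a range from 300 nM to 1600 nM. This estimate means an expected step of a 1.3-fold higher number from compound 1 to compound 4 (0.11 log units; within the scatter).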

Compound 4, half-maximal inhibitory concentration: 153 nM
Compound 4: middle estimate off by 4.6-fold (0.66 log units), on the high side, and the stated range ends above it.
By their numbers in this assay, from the lowest: compounds 4 and 3 (each within the scatter of the next); then compounds 2 and 1 (each within the scatter of the next).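

In this assay, hydrogen in place of hydroxy on a saturated chain carbon bound to a double-bonded ring carbon, which turns hydroxymethyl into methyl, gives a 3.5-fold lower number from compound 1 to compound 4 (0.55 log units; beyond the scatter) and so moves toward stronger inhibition. Going by these compounds alone, this pair is the first look at this position, which no earlier comparison could give, and it shows that inhibition here does not depend on the hydroxy and that this one small change moves the number beyond the scatter. No measurement at hand accounts for the step, so the pair gives its size and direction but no cause.

Going by these compounds, whether an aminomethyl, a methoxymethyl, a carboxylic acid or a longer chain at this carbon would follow the methyl or the hydroxymethyl stays open. One pair also leaves open whether the step would hold with a different amide group on the shared core.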